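Piperidine amide in place of methylamide: compound 3

The source may hold more compounds than are shown below. What is called first, only, known or untested is meant among the compounds shown, and "the series" means these compounds.

Measured in an ADME assay (liver) for metabolic stability, with Liver microsome (Homo sapiens) as the target, using microsomes; a lower number here means slower removal, a higher number faster removal of the compound:
- compound 1 `Cc1ccc(Oc2cc(C(=O)Nc3cnc(C)cn3)cc3oc(C)cc23)cc1`: 47 mL/min/kg
- compound 2 `CNC(=O)c1cnc(Oc2cc(C(=O)Nc3cnc(C)cn3)cc3oc(C)cc23)cn1`: 10.1 mL/min/kg

Of the two numbers, compound 2 holds the lower, at 10.1 mL/min/kg. Going by the values given here, the only measured step, a 4.7-fold lower number from compound 1 to compound 2 (0.67 log units; beyond the scatter), put 5-(methylcarbamoyl)pyrazin-2-yl in place of 4-methylphenyl on an oxygen on an aromatic ring.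

Compound 3 `Cc1cnc(NC(=O)c2cc(Oc3cnc(C(=O)N4CCCCC4)cn3)c3cc(C)oc3c2)cn1` carries piperidin-1-yl in place of methylamino on a carbonyl carbon, so methylcarbamoyl becomes (piperidin-1-yl)carbonyl: piperidin-1-yl in place of methylamino on a carbonyl carbon. Among the compounds with values here, no measured step covers this exchange directly. The nearest evidence is the step above, a 4.7-fold lower number from compound 1 to compound 2 (0.67 log units; beyond the scatter), which brought in the methylcarbamoyl group now being altered. Within the data shown here, with only that step to go on, part of that drop may be given back while the rest of the entering group stays. The expected move is therefore upward and smaller than the measured one, and none beyond the scatter remains possible: a 2.0-fold higher number from compound 2 to compound 3 (0.30 log units; within the scatter) is the estimated step. The estimate for compound 3 is 20 mL/min/kg, with an expected range of 10 mL/min/kg to 40 mL/min/kg.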

Compound 3, clearance: 18.2 mL/min/kg
Beside the measured number, compound 3's estimate is 1.1-fold (0.04 log units) above it; the measured number falls inside the stated range.
By their numbers in this assay, from the lowest: compounds 2 and 3 (each within the scatter of the next); then compound 1.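

In this assay, piperidin-1-yl in place of methylamino on a carbonyl carbon gives a 1.8-fold higher number from compound 2 to compound 3 (0.26 log units; within the scatter), so this exchange cannot be told apart from the scatter. The earlier step showed only the effect of replacing the whole group on the oxygen; this one shows that the end of the amide can go from methylcarbamoyl to (piperidin-1-yl)carbonyl, with more heavy atoms, a six-membered non-aromatic ring and no amide hydrogen, and the read-out stays within the scatter. The compounds shown offer nothing that explains this outcome.

With a single exchange at this carbonyl carbon, no trend with the size or shape of the amine part can be drawn, and the result cannot be extended to other amides. Still open, as far as these compounds go, is how this read-out responds to an open-chain dimethylamino group, a morpholin-4-yl or piperazin-1-yl ring, or a carboxylic acid in place of the amide, and whether a primary amide, which keeps both amide hydrogens, stays within the scatter of compound 2.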